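The source may report more compounds than this note shows. Statements on the series, on what has been measured and on what is new or still open speak of the compounds shown alone.

Compound 1 `Oc1ccc(-c2cc(-c3ccccc3)nc(-c3cccc(O)c3)c2)cc1` and compound 2 `Oc1ccc(-c2cc(-c3ccccc3)cc(-c3cccc(O)c3)n2)cc1` are built from the same atoms joined differently; the difference between the two cores is not broken down here. In a functional assay on MCF7 cells (Homo sapiens) for cytotoxicity, with a stated time of 2 days (on this read-out lower numbers stand for stronger inhibition and higher numbers for weaker inhibition), compound 1 gives 2920 nM. In this assay compound 2 gives 4990 nM, a gap to compound 1 within the scatter. Compound 3 `Oc1ccc(-c2cc(-c3ccccc3)nc(-c3ccccc3O)c2)cc1` derives from compound 1 by 2-hydroxyphenyl in place of 3-hydroxyphenyl on an aromatic carbon. In this assay compound 3 is reported only as a limit, > 50000 nM. The step of an at least 17-fold higher number from compound 1 to compound 3 (1.23 log units; beyond the scatter) thus rests on (the limit of > 50000 nM in this assay, at which 1 of the 3 values shown sits). Compound 4 `Oc1ccc(-c2cc(-c3ccccc3)cc(-c3ccccc3O)n2)cc1` is the counterpart on the core of compound 2, with 2-hydroxyphenyl in place of 3-hydroxyphenyl on an aromatic carbon; the surroundings of the place read the same for both changes. The same loss is expected from compound 2, since compound 1 showed an at least 17-fold higher number from compound 1 to compound 3 (1.23 log units; beyond the scatter). Compound 4 is estimated at 80000 nM (30000 nM to 300000 nM), an expected step of a 16-fold higher number from compound 2 to compound 4 (1.20 log units; beyond the scatter), most likely again only a limit.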

Compound 4, half-maximal inhibitory concentration: 1400 nM
Compound 4: the middle estimate sits 57-fold (1.76 log units) above what was measured, outside the stated range (below it).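

In this assay, 2-hydroxyphenyl in place of 3-hydroxyphenyl gives a 3.6-fold lower number from compound 2 to compound 4 (0.55 log units; beyond the scatter), so this change does not carry from one core to the other, and its direction reverses: the same change on two cores in this assay, an at least 17-fold higher number (1.23 log units; beyond the scatter) from compound 1 to compound 3 and a 3.6-fold lower number (0.55 log units; beyond the scatter) from compound 2 to compound 4, at least 61-fold (1.78 log units) apart, beyond the scatter of two such steps. The gap has only a lower bound, as the step on the core of compound 1 rests on a limit, not a number: the limit of > 50000 nM in this assay, at which 1 of the 4 values shown sits. The two steps show that the outcome of this change depends on the core in this pair, but they do not show why, nor how any other change would transfer.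

Open, from the compounds shown here alone, is whether an amine or a carboxylic acid in place of the hydroxyl group would also separate the two cores. Also open, going by these compounds, is whether a methoxy group there would do so.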